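Inverting the ring stereocentre of compound 2

The source may report more compounds than this note shows. Statements on the series, on what has been measured and on what is new or still open speak of the compounds shown alone.

In an in vivo ADME assay on the whole organism (plasma) for pharmacokinetics, with Rattus norvegicus as the target, at a dose of 3 mg/kg (a higher number here means faster removal of the compound, a lower number slower removal), compound 1 `CN(C1CCCn2c1nc(C(=O)NCc1ccc(F)cc1)c(O)c2=O)S(C)(=O)=O` gives 48 mL/min/kg and compound 2 `CN(C)S(=O)(=O)N(C)[C@@H]1CCCn2c1nc(C(=O)NCc1ccc(F)cc1)c(O)c2=O` gives 1.8 mL/min/kg as the lower of the two numbers, a gap beyond the scatter. Compound 3 `CN(C)S(=O)(=O)N(C)[C@H]1CCCn2c1nc(C(=O)NCc1ccc(F)cc1)c(O)c2=O` has not been measured. It keeps the atoms and bonds of compound 2 and differs by the two compounds have the same atoms and bonds and differ only in configuration as drawn: 1 of 1 stereo elements differ; a stereocentre at a saturated ring carbon is drawn R in compound 2 and S in compound 3 in configuration as drawn: a stereocentre at a saturated ring carbon is drawn R in compound 2 and S in compound 3. Among the measured compounds shown here, no measured pair shows the effect of a change in configuration, so any forecast here is loose. A modest rise is expected rather than a fall, since compound 2 at 1.8 mL/min/kg already lies low. The expected move is a 2.8-fold higher number from compound 2 to compound 3 (0.44 log units; beyond the scatter) on this estimate. For compound 3 the estimated value is 5 mL/min/kg with an expected range from 1.5 mL/min/kg to 20 mL/min/kg in this read-out.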

Compound 3, clearance: 14 mL/min/kg
Compound 3: the middle estimate sits 2.8-fold (0.45 log units) below what was measured; the measured number falls inside the stated range.
By their numbers in this assay, from the lowest: compound 2; then compound 3; then compound 1.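

Drawing the stereocentre at a saturated ring carbon as S rather than R gives a 7.8-fold higher number from compound 2 to compound 3 (0.89 log units; beyond the scatter) in this assay. Among the compounds shown here, this is the only measured pair that isolates configuration, and the step can be assigned to configuration alone because nothing else separates the two compounds: the fact that compounds 2 and 3 differ only in the configuration as drawn. Removal in this pair therefore depends on how this one carbon is drawn, with the R form the more slowly cleared, while compound 1, drawn without a configuration at that carbon, adds no reading on this point.

Going by these compounds, whether inversion gives a step of similar size with another group at this carbon, such as a primary amine or a carboxylic acid, stays open. A single pair also cannot say why the two forms differ in removal.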